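A few compounds are considered here, and "the series" means these few. Any claim that something is new, unique, unknown or untested is made for them only; others in the source may bear on it.

Of the compounds shown here, two have been measured in an assay on isolated protein (strain Sprague-Dawley) for inhibition of Amine oxidase [flavin-containing] A (Rattus norvegicus), read by spectrophotometry, with a stated time of 5 min, tested at 10 uM; a higher number here means more inhibition at the concentration tested (going by the name of the read-out), a lower number less inhibition. Compound 1, `O=c1cc(Oc2ccccc2)c2ccc(OCc3cccc(Cl)c3)cc2o1`, gives 0%. Compound 2, `O=Cc1cc(=O)oc2cc(OCc3cccc(Cl)c3)ccc12`, gives 14%, and so stands highest of the two numbers, with compound 1 lower by a margin beyond the scatter. Within the data shown here, the one measured step, a number 14 percentage points higher from compound 1 to compound 2 (beyond the scatter), exchanges a phenoxy group for a formyl group on an aromatic carbon of the shared core, and is the only comparison available so far.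

Compound 3, `O=C(O)c1cc(=O)oc2cc(OCc3cccc(Cl)c3)ccc12`, differs from compound 2 only by hydroxy in place of hydrogen on a carbonyl carbon; cut one bond further out, this reads as formyl to carboxy. Among the measured compounds shown here, no measured step bears on this change: the step from compound 1 to compound 2 replaced a different group at a different place, so its size offers no guide here. With nothing to lean on, the expectation is a step of no more than the scatter in this assay, in either direction. Compound 3 is therefore estimated to give 12%, within 0% to 30%, which corresponds to an expected step of a number 2 percentage points lower from compound 2 to compound 3 (within the scatter).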

Compound 3, a percentage reported as inhibition, at one concentration (the size of the read-out at that concentration, not a potency): 0%
Estimate against measurement, compound 3: 12 percentage points above; the range from low to high includes it.
By their numbers in this assay, from the lowest: compounds 1 and 3 (each within the scatter of the next); then compound 2.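

In this assay, putting hydroxy in place of hydrogen on the carbonyl carbon turns formyl into carboxy and gives a number 14 percentage points lower from compound 2 to compound 3 (beyond the scatter), so a change of one heavy atom at this place is enough to move the read-out beyond the usual scatter. The other new comparison, with carboxy in place of phenoxy on the aromatic carbon, gives no change at the digits printed from compound 1 to compound 3 (within the scatter), which means these two very different groups cannot be told apart here, and among the three groups shown, only formyl stands apart from the others. Nothing available explains why the formyl compound differs from the carboxy compound.

From the compounds shown here alone, it remains open whether an amide, a methyl ester or an amine on the same aromatic carbon would match compound 2 or fall level with compound 1 and compound 3. Even compound 2 reaches only 14% at the single concentration tested, so these numbers give no potency and leave open whether any group at this place could produce much stronger inhibition.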